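The compounds below may be only part of what the source reports. "The series", "measured", "known", "first", "only" and "open" are said of these compounds alone.

Of the compounds shown here, three of a shared core have so far been measured in a functional assay for inhibition, with Homo sapiens as the target; on this read-out lower numbers stand for stronger inhibition and higher numbers for weaker inhibition. Compound 1 `c1coc(-c2ccnc(Nc3ccc(-n4ccnc4)cc3)n2)c1` gives 2200 nM. Compound 2 `CC(=O)N(C)c1ccc(Nc2nccc(-c3cccnc3)n2)cc1` gives 900 nM. Compound 3 `CC(=O)N(C)c1ccc(Nc2nccc(-c3ccncc3)n2)cc1` gives 500 nM. Compound 2 thus stands in the middle of the three numbers: its value and that of compound 3 lie within the usual scatter of each other, so no order can be read between them, while the value of compound 1 lies beyond the scatter above that of compound 2.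

Among the compounds with values here, the only step measured between neighbours is a 1.8-fold lower number from compound 2 to compound 3 (0.26 log units; within the scatter), which concerns the position of the ring nitrogen and stays within the scatter.

Compound 4 `CN(C)c1ccc(Nc2nccc(-c3cccnc3)n2)cc1` is not yet measured. It differs from compound 2 at the nitrogen on the aromatic ring whose other neighbours are an aromatic carbon and a saturated chain carbon: methyl in place of acetyl on a nitrogen on an aromatic ring. Within the data shown here, no measured step touches this nitrogen, so no direct precedent exists for the change from acetyl(methyl)amino to dimethylamino; the one step known, from a ring-nitrogen shift, changed nothing beyond the scatter. Compound 4 is therefore expected to stay close to compound 2, with an estimated no change at the digits printed from compound 2 to compound 4 (within the scatter) in this assay. The estimate for compound 4 is 900 nM, in a range from 300 nM to 2700 nM.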

Compound 4, half-maximal inhibitory concentration: 2800 nM
For compound 4 the middle estimate is 3.1-fold (0.49 log units) below the measured one; the measured number lies above the stated range.
By their numbers in this assay, from the lowest: compounds 3 and 2 (each within the scatter of the next); then compounds 1 and 4 (each within the scatter of the next).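

In this assay, the nitrogen on an aromatic ring turns out to be a place where the group matters: methyl in place of acetyl gives a 3.1-fold higher number from compound 2 to compound 4 (0.49 log units; beyond the scatter), whereas the change in ring-nitrogen position, a 1.8-fold lower number from compound 2 to compound 3 (0.26 log units; within the scatter), gave no order that could be read. Acetyl and methyl differ in several counted ways at once: the acetyl group has 3 heavy atoms, a double bond outside aromatic rings and 1 hydrogen-bond acceptor, while methyl has 1 heavy atom and no hydrogen-bond acceptor, so this single step cannot separate their contributions. No independent evidence bears on this result, and the step therefore stands as an observation without an established explanation.

The compounds shown leave open whether a propanoyl group, a formyl group or a methanesulfonyl group on this nitrogen would give numbers closer to those of the acetyl compound or of the methyl compound. They also leave open whether methyl in place of acetyl would give a step of similar size when pyridin-4-yl stands in place of pyridin-3-yl.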